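The source may hold more compounds than are shown below. What is called first, only, known or untested is meant among the compounds shown, and "the series" means these compounds.

Compound 1 `O=C(O)CCCc1ccc(NCc2cccc(Oc3ccccc3)c2)cc1` gives 1120 nM in a functional assay on CHO cells for agonist activity at Free fatty acid receptor 1 (Homo sapiens); a higher number here means that more compound is needed for the effect, a lower number that less compound is needed.
Compound 2 `Cc1nc(-c2ccc(C(F)(F)F)cc2)sc1CNc1ccc(OCC(=O)O)cc1` gives 288 nM in this assay.
Compound 3 `CC(C)(Oc1ccc(NCc2cccc(Oc3ccccc3)c2)cc1)C(=O)O` gives < 10000 nM in this assay, which is a limit of the assay and not a number.

Of the two numbers that can be read, compound 2 has the lower one; compound 1 stands beyond the scatter above it, so compound 2 needs less compound for the effect than compound 1. Compound 3 sits at the limit of < 10000 nM in this assay, at which 1 of the 3 values shown sits.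

Compound 4 `Cc1nc(-c2ccc(C(F)(F)F)cc2)sc1CNc1ccc([C@H]2C[C@@H]2C(=O)NC2CCNC2)cc1` differs from compound 2 in one place: 2-((pyrrolidin-3-yl)carbamoyl)cyclopropyl in place of carboxymethoxy on an aromatic carbon. Within the data shown here, the only measured step, from compound 1 to compound 3, is a step that the limit leaves unreadable from compound 1 to compound 3, so its size cannot be read; it also concerns a different group and keeps a carboxylic acid on both sides. Among the measured compounds shown here, no measured step therefore bears on the change from compound 2 to compound 4. Every measured compound carries a carboxylic acid, and compound 4 would be the first without one, so the data give no guide to the size of the step. On that footing compound 4 is expected to need more compound than compound 2, an estimated step of a 17-fold higher number from compound 2 to compound 4 (1.24 log units; beyond the scatter). The estimate for compound 4 is 5000 nM, with a range from 700 nM to 30000 nM, and a real chance that only a limit is reported.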

Compound 4, half-maximal effective concentration: 204 nM
Beside the measured number, compound 4's estimate is 25-fold (1.39 log units) above it; the whole stated range lies above it.
By their numbers in this assay, from the lowest: compounds 4 and 2 (each within the scatter of the next); then compound 1.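

In this assay the exchange of 2-((pyrrolidin-3-yl)carbamoyl)cyclopropyl for carboxymethoxy is a 1.4-fold lower number from compound 2 to compound 4 (0.15 log units; within the scatter), so this position on an aromatic carbon, para to a large group, takes the much larger group with no difference that can be told from the scatter. Compounds 1, 2 and 3 all carry a carboxylic acid and could not show this, whereas compound 4 has none and still stands level with compound 2, so on this core a carboxylic acid at this position is not required for a number of this size. Nothing among the values shown gives a reason for this result.

Compound 4 brings in the cyclopropyl, the amide and the pyrrolidin-3-yl ring in a single step, so the compounds shown do not separate what each part contributes at this position. In this assay, on these data alone, it also stays open how a cyclopropyl bearing a carboxylic acid, or an amide carrying a piperidine in place of the pyrrolidine ring, would compare on this core.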